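A few compounds are considered here, and "the series" means these few. Any claim that something is new, unique, unknown or untested is made for them only; others in the source may bear on it.

Compound 2 `COc1cccc(Oc2ccc3c(NCCCNCc4ccco4)ccnc3c2)c1` serves as the reference for this step. In an ADME assay for permeability, using PAMPA, with a stated time of 30 min, at pH 7.4 (a lower number here means that the compound crosses the layer more slowly, a higher number that the compound crosses the layer faster), compound 2 gives 317 10^-6 cm/s, which puts it level with compound 1 `CC(C)(C)c1ccc(Oc2ccc3c(NCCCNCc4ccco4)ccnc3c2)cc1`, since in this assay compound 1 gives 317 10^-6 cm/s. Going by the values given here, the one measured step connecting them, no change at the digits printed from compound 1 to compound 2 (within the scatter), therefore shows no difference beyond the usual scatter, even though the two compounds carry quite different groups on the aryl ether.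

Compound 3 `CN(C)c1cccc(Oc2ccc3c(NCCCNCc4ccco4)ccnc3c2)c1` is obtained from compound 2 by a single change: dimethylamino in place of methoxy on an aromatic carbon. Among the compounds with values here, no measured pair in this set exchanges a methoxy for a dimethylamino, so there is no direct precedent. Within the data shown here, the only step that bears on it is the one from compound 1 to compound 2, in which a change of the group on the same aryl ether left this assay unchanged within the scatter. On that basis, and given that the leaving and entering groups are both small and uncharged, the step from compound 2 to compound 3 is expected to be no change at the digits printed from compound 2 to compound 3 (within the scatter), that is, no change beyond the scatter. Compound 3 is accordingly estimated to give 317 10^-6 cm/s in this assay, with a plausible range from 160 10^-6 cm/s to 500 10^-6 cm/s.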

Compound 3, apparent permeability: 317 10^-6 cm/s
Compound 3: middle estimate and measured number agree at the digits printed, within the range that was stated.
By their numbers in this assay, from the lowest: compounds 1, 2 and 3 (each within the scatter of the next).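

In this assay, going by these compounds alone, dimethylamino in place of methoxy on an aromatic carbon gives no change at the digits printed from compound 2 to compound 3 (within the scatter), which is the first measured exchange in this set of one group for another on the same 3-substituted phenyl ring, with the position on that ring held constant. Set against the 4-(tert-butyl)phenyl group, the 3-(dimethylamino)phenyl group gives no change at the digits printed from compound 1 to compound 3 (within the scatter), so the three aryl groups on this ether oxygen now stand within the scatter of one another in this assay, and the earlier flat step no longer rests on a single pair. No measurement is at hand that would explain this flat result.

Whether the same holds for a carboxylic acid or a primary amine on this ring stays open, since both groups differ from methoxy and dimethylamino in kind and neither appears among the compounds shown. Also open, as far as these compounds go, is whether the read-out would stay level with a methylene in place of the ether oxygen, or with a longer chain in place of the one on the shared core.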